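Carbamate aryl fluorine position in the shared core

The compounds below may be only part of what the source reports. "The series", "measured", "known", "first", "only" and "open" are said of these compounds alone.

Compound 1 `CC(C)=CCC/C(C)=C/CC1Cc2c(OCc3ccccc3)cc(=O)n(CCCO)c2CC1(C)C` carries a benzyl group on the ring oxygen of the shared core; compound 2 `CC(C)=CCC/C(C)=C/CC1Cc2c(OC(=O)Nc3ccc(F)cc3)cc(=O)n(CCCO)c2CC1(C)C` carries a (4-fluorophenyl)carbamoyl group there instead. In a functional assay on PANC-1 cells (Homo sapiens) for inhibition, read by MTT assay, with a stated time of 24 h, tested at 10 uM (a higher number here means more inhibition at the concentration tested (going by the name of the read-out), a lower number less inhibition), compound 1 gives 1.5%, and in this assay compound 2 gives 6.2%. Going by the values given here, the step of a number 4.7 percentage points higher from compound 1 to compound 2 (within the scatter) is the only measured step in the set, and it does not separate the two compounds: compound 2 has the higher of the two numbers, but its distance from compound 1 lies within the scatter, so the inhibition in this assay of the two compounds is level.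

Compound 3 `CC(C)=CCC/C(C)=C/CC1Cc2c(OC(=O)Nc3ccccc3F)cc(=O)n(CCCO)c2CC1(C)C` differs from compound 2 by 2-fluorophenyl in place of 4-fluorophenyl on an amide-type nitrogen. Among the compounds with values here, no measured step moves the fluorine on the carbamate aryl ring; the one step known, from compound 1 to compound 2, exchanges the whole group on the oxygen and is itself within the scatter. There is therefore no basis to expect a step beyond the scatter in this assay, in either direction. Compound 3 is expected to give 6% in this assay, between -4% and 16%. The expected step is thus a number 0.2 percentage points lower from compound 2 to compound 3 (within the scatter), essentially none.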

Compound 3, a percentage reported as inhibition, at one concentration (the size of the read-out at that concentration, not a potency): 0%
Compound 3: middle estimate off by 6 percentage points, on the high side; measured number inside the range.
By their numbers in this assay, from the lowest: compounds 3, 1 and 2 (each within the scatter of the next).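

Going by these compounds alone, exchanging 4-fluorophenyl for 2-fluorophenyl on the amide-type nitrogen gives a number 6.2 percentage points lower from compound 2 to compound 3 (within the scatter) in this assay, the first measured step that changes only where the fluorine sits on the carbamate aryl ring, and it does not separate the two compounds. The exchange of the whole group on the oxygen now has a second reading, a number 1.5 percentage points lower from compound 1 to compound 3 (within the scatter), so with either fluorophenyl carbamate the step away from the benzyl group stays within the scatter, and compound 1, compound 2 and compound 3 all read as level in this assay. No evidence on the cause of this flat result is available for these compounds.

From the compounds shown here alone, all the steps in the set lie within the scatter, so it remains open whether any change on the carbamate aryl ring or on the ring oxygen of the shared core can produce a step beyond it in this assay. The informative next groups would be an amine or a carboxylic acid in place of the fluorine on the aryl ring, or a longer chain in place of the benzyl group on the oxygen, since a group of a different kind might show whether this position responds at all.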